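This account rests on a few compounds, and the source may have more. Where it says the series, first, only, none or still open, it means among the compounds named here.

Values in a functional assay on HCT-116 cells (Homo sapiens) for inhibition, read by CCK-8 assay, with a stated time of 48 h; a higher number here means a weaker inhibitor, a lower number a stronger inhibitor:
- Compound 1 `COc1ccc(CN(C(=O)CSC(=S)N2CCN(C)CC2)c2cc(OC)c(OC)c(OC)c2)cc1`: 2640 nM
- Compound 2 `COc1ccc(CN(C(=O)CSC(=S)N2CCCC2)c2cc(OC)c(OC)c(OC)c2)cc1`: 4970 nM
- Compound 3 `COc1ccc(CN(C(=O)CSC(=S)N2CCCc3cc(C)ccc32)c2cc(OC)c(OC)c(OC)c2)cc1`: 5230 nM

Compound 3, at 5230 nM, cannot be separated from the other two measured compounds, since every step among them lies within the scatter. The next change, on a thiocarbonyl carbon, leads to compound 4 `COc1ccc(CN(C(=O)CSC(=S)N2CCc3ccccc3C2)c2cc(OC)c(OC)c(OC)c2)cc1`: 1,2,3,4-tetrahydroisoquinolin-2-yl in place of 6-methyl-1,2,3,4-tetrahydroquinolin-1-yl on a thiocarbonyl carbon.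

All three measured steps bear on this change, as each replaces the group at that same place: a 1.9-fold higher number from compound 1 to compound 2 (0.27 log units; within the scatter), a 2.0-fold higher number from compound 1 to compound 3 (0.30 log units; within the scatter) and a 1.1-fold higher number from compound 2 to compound 3 (0.02 log units; within the scatter). Across these compounds, exchanging the group has therefore not moved the number beyond the scatter. Within the data shown here, no measured compound carries 1,2,3,4-tetrahydroisoquinolin-2-yl, so the expectation rests on these steps alone and remains uncertain.

No step beyond the scatter is expected in this assay, and the estimate is placed among the three measured values. The estimated change is a 1.2-fold lower number from compound 3 to compound 4 (0.10 log units; within the scatter). The estimate for compound 4 is 4200 nM, with an expected range of 1900 nM to 9000 nM.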

Compound 4, half-maximal inhibitory concentration: 15900 nM
The estimate for compound 4 lay 3.8-fold (0.58 log units) below the measured number; the whole stated range lies below it.
By their numbers in this assay, from the lowest: compounds 1, 2 and 3 (each within the scatter of the next); then compound 4.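

In this assay, the group on the thiocarbonyl carbon now makes a difference beyond the scatter, as 1,2,3,4-tetrahydroisoquinolin-2-yl separates from all three earlier groups: a 3.0-fold higher number from compound 3 to compound 4 (0.48 log units; beyond the scatter), a 3.2-fold higher number from compound 2 to compound 4 (0.51 log units; beyond the scatter) and a 6.0-fold higher number from compound 1 to compound 4 (0.78 log units; beyond the scatter). The leaving 6-methyl-1,2,3,4-tetrahydroquinolin-1-yl and the entering 1,2,3,4-tetrahydroisoquinolin-2-yl have the same ring types and the same hydrogen-bond donor and acceptor counts, so these descriptors alone do not account for the number at this position. Nothing available explains why this group stands apart from the other three.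

The compounds shown do not separate the loss of the methyl group from the change from the tetrahydroquinoline to the tetrahydroisoquinoline arrangement, a question the unsubstituted 1,2,3,4-tetrahydroquinolin-1-yl would address. Also open, on these data alone, is where simple saturated amines such as piperidin-1-yl or morpholin-4-yl would fall, and whether any group on the thiocarbonyl carbon can give a number clearly lower than that of the 4-methylpiperazin-1-yl in compound 1.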